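Piperidine nitrogen substituent series: permeability notes

A few compounds are considered here, and "the series" means these few. Any claim that something is new, unique, unknown or untested is made for them only; others in the source may bear on it.

Compound 2 `Cn1cncc1CN1CC(N(CC2CCN(C(=O)CC(C)(C)C)CC2)S(=O)(=O)c2ccccn2)Cc2cc(C#N)ccc21` gives 0.5 10^-6 cm/s in an ADME assay on Caco-2 cells (Homo sapiens) for permeability, in the apical to basolateral direction; a lower number here means that the compound crosses the layer more slowly, a higher number that the compound crosses the layer faster. Compound 1 `Cn1cncc1CN1CC(N(CC2CCN(C(=O)CNC(=O)OC(C)(C)C)CC2)S(=O)(=O)c2ccccn2)Cc2cc(C#N)ccc21` gives 0.5 10^-6 cm/s in this assay; compound 2 stands level with compound 1 at the digits shown, the two together being the lowest of the three numbers in hand. Compound 3 `Cn1cncc1CN1CC(N(Cc2cccc(-n3cccc3)c2)S(=O)(=O)c2ccccn2)Cc2cc(C#N)ccc21` gives 2.3 10^-6 cm/s and is the furthest from compound 2, but it differs from compound 2 in more than one place, so only the two values themselves can be set side by side.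

The unmeasured compound 4 `Cn1cnc(S(=O)(=O)N2CCC(CN(C3Cc4cc(C#N)ccc4N(Cc4cncn4C)C3)S(=O)(=O)c3ccccn3)CC2)c1` differs from compound 2 as follows: (1-methyl-1H-imidazol-4-yl)sulfonyl in place of neopentylcarbonyl on an amine nitrogen in a ring.

Among the compounds with values here, the one measured step in this region, no change at the digits printed from compound 1 to compound 2 (within the scatter), changed a saturated chain group on the same carbonyl and left the read-out unchanged within the scatter. Within the data shown here, no measured step exchanges the carbonyl itself for a sulfonyl on that ring nitrogen, so the bearing of that step on compound 4 is indirect. The step from compound 2 to compound 4 is expected to be a 1.3-fold lower number from compound 2 to compound 4 (0.10 log units; within the scatter), that is, no change beyond the scatter, with the estimate leaning slightly downward. Compound 4 is estimated at 0.4 10^-6 cm/s, in the range 0.15 10^-6 cm/s to 1.2 10^-6 cm/s.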

Compound 4, apparent permeability: 0.1 10^-6 cm/s
Compound 4: middle estimate off by 4.0-fold (0.60 log units), on the high side; measured number below the stated range.
By their numbers in this assay, from the lowest: compound 4; then compounds 1 and 2 (each within the scatter of the next); then compound 3.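

Exchanging the acyl group on the amine nitrogen in the ring for a sulfonyl group moves the read-out in this assay: there is a 5.0-fold lower number from compound 2 to compound 4 (0.70 log units; beyond the scatter), and likewise a 5.0-fold lower number from compound 1 to compound 4 (0.70 log units; beyond the scatter). The earlier change of chain on the same carbonyl, with no change at the digits printed from compound 1 to compound 2 (within the scatter), gave no sign that this position could shift the number, so among these three compounds the (1-methyl-1H-imidazol-4-yl)sulfonyl exchange counts for more than the choice of chain on the carbonyl. No measurement in hand accounts for this step.

The exchange replaces the carbonyl with a sulfonyl and the saturated chain with an aromatic ring at once, and the compounds shown do not separate the two. Methylsulfonyl or phenylsulfonyl on the same ring nitrogen, or (1-methyl-1H-imidazol-4-yl)carbonyl, would show which part goes with the step.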